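Changing one side group on a shared core

The compounds below may be only part of what the source reports. "The series", "measured", "known", "first", "only" and "open" are said of these compounds alone.

Among the measured compounds shown here, in a functional assay on A549 cells (Homo sapiens) for antiproliferative activity, read by MTT assay, with a stated time of 48 h (on this read-out higher numbers stand for weaker inhibition and lower numbers for stronger inhibition), compound 3 (`CC[Si](CC)(CC)C/C1=C/C[C@](C)(CCC=C(C)C)/C=C/[C@@H](OC(=O)C=C(C)C)[C@](C)(O)/C=C/C1=O`) gives 3100 nM, the highest number so far and so the weakest inhibition. Compound 1 (`CCN(CC)C/C1=C/C[C@](C)(CCC=C(C)C)/C=C/[C@@H](OC(=O)C=C(C)C)[C@](C)(O)/C=C/C1=O`) gives 130 nM, and compound 2 (`CC(C)=CCC[C@]1(C)/C=C/[C@@H](OC(=O)C=C(C)C)[C@](C)(O)/C=C/C(=O)/C(CN2CCN(C)CC2)=C\C1`) gives 940 nM. Compound 4 (`CC(C)=CCC[C@]1(C)/C=C/[C@@H](OC(=O)C=C(C)C)[C@](C)(O)/C=C/C(=O)/C(COC(=O)c2ccc([N+](=O)[O-])cc2)=C\C1`) keeps the shared core but carries ((4-nitrophenyl)carbonyl)oxy on a saturated chain carbon bound to a double-bonded ring carbon: a group of 12 heavy atoms (7 carbon, 1 nitrogen, 4 oxygen; one six-membered aromatic ring of carbon only) in place of a group of 7 heavy atoms (6 carbon, 1 silicon; no ring), on a saturated chain carbon bound to a double-bonded ring carbon. All measured steps change this same place: a 24-fold higher number from compound 1 to compound 3 (1.38 log units; beyond the scatter) is large, while a 3.3-fold higher number from compound 2 to compound 3 (0.52 log units; beyond the scatter) and a 7.2-fold higher number from compound 1 to compound 2 (0.86 log units; beyond the scatter) are modest. None brings in this ester group, so the guide is only indirect. With compound 3 at the top of the range, a modest fall is expected. The estimated change is a 3.1-fold lower number from compound 3 to compound 4 (0.49 log units; beyond the scatter). For compound 4 the expected value is 1000 nM, within an estimated range of 250 nM to 3500 nM.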

Compound 4, half-maximal inhibitory concentration: 1310 nM
The estimate for compound 4 lay 1.3-fold (0.12 log units) below the measured number; measured number inside the range.
By their numbers in this assay, from the lowest: compound 1; then compounds 2 and 4 (each within the scatter of the next); then compound 3.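

In this assay, the ester group improves on the silicon-bearing group, with a 2.4-fold lower number from compound 3 to compound 4 (0.37 log units; beyond the scatter), so a large aromatic ester is not the poorest choice at this position among those shown. Against the 4-methylpiperazin-1-yl group, a 1.4-fold higher number from compound 2 to compound 4 (0.14 log units; within the scatter), which leaves the two groups indistinguishable here, although a 10-fold higher number from compound 1 to compound 4 (1.00 log units; beyond the scatter) shows that neither matches diethylamino. Nothing available explains these differences.

Going by these compounds, it remains open how a plain benzoyloxy group, lacking the nitro group, would compare with the ester of compound 4. On these data alone, it is also open whether a smaller amine such as dimethylamino would match diethylamino.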